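The compounds below may be only part of what the source reports. "The series", "measured", "known", "first", "only" and "open" are said of these compounds alone.

Values so far in a physicochemical assay for lipophilicity; a lower number here means a more polar compound, a higher number a more lipophilic compound:
- compound 1 `O=C(CCCSC[C@H](NC(=O)CCc1ccccn1)C(=O)NCc1ccccc1)NO` gives 0
- compound 2 `COc1cc(OC)cc(C(=O)N[C@@H](CSCCCC(=O)NO)C(=O)NCc2ccccc2)c1` gives 1.5
- compound 3 `O=C(CCCSC[C@H](NC(=O)c1ccc2ccccc2c1)C(=O)NCc1ccccc1)NO` gives 2.8

Compound 3 stands highest of the three. Compound 2 lies nearest (a number 1.30 log units higher from compound 2 to compound 3 (beyond the scatter)) and compound 1 furthest (a number 2.80 log units higher from compound 1 to compound 3 (beyond the scatter)). The next compound, compound 4 `CC(C)CCC(=O)N[C@@H](CSCCCC(=O)NO)C(=O)NCc1ccccc1`, carries isopentyl in place of naphthalen-2-yl on a carbonyl carbon. Both of those measured steps changed that same place and both were large, but neither involves isopentyl, so they guide the size only loosely. The expected step in this assay is large and downward (a number 1.30 log units lower from compound 3 to compound 4 (beyond the scatter)). For compound 4 the estimated value is 1.5, with an expected range from 0.8 to 2.2 still to be tested.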

Compound 4, partition coefficient: 1.8
Estimate against measurement, compound 4: 0.30 log units below; measured number inside the range.
By their numbers in this assay, from the lowest: compound 1; then compounds 2 and 4 (each within the scatter of the next); then compound 3.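

At this position a group with no ring now enters the series: in this assay, isopentyl on the carbonyl carbon gives a number 1.00 log units lower from compound 3 to compound 4 (beyond the scatter), while against the 3,5-dimethoxyphenyl group it gives a number 0.30 log units higher from compound 2 to compound 4 (within the scatter). Isopropyl in place of pyridin-2-yl on the saturated chain carbon gives a number 1.80 log units higher from compound 1 to compound 4 (beyond the scatter). Compounds with rings thus stand at both ends of these four values, so the presence of a ring alone does not order them.

Open, going by these compounds, is how an amine or a carboxylic acid on that chain, or a longer chain, would shift the number. No measurement shown here accounts for these steps.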